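The compounds below may be only part of what the source reports. "The series", "measured", "known", "first", "only" and "open" are said of these compounds alone.

The account follows a single step, from compound 1 `Cc1ccc(N2CCN(CC(=O)N(c3ccccc3)c3ccccc3)CC2)cc1` to compound 4 `COc1ccccc1N1CCN(CC(=O)N(c2ccccc2)c2ccccc2)CC1`, in a toxicity assay on the whole organism (strain albino) for activation, with Mus musculus as the target, with stated times of 30 min and 240 min; on this read-out lower numbers stand for an effect already at smaller amounts and higher numbers for an effect only at larger amounts of compound. Compound 1 stands at a limit of the assay rather than at a number: in this assay compound 1 gives > 40 mg/kg. Compound 2 `Cc1cccc(N2CCN(CC(=O)N(c3ccccc3)c3ccccc3)CC2)c1C` also reaches only a limit, and in this assay compound 2 gives > 40 mg/kg. For the measured compounds named here, compound 3 `O=C(CN1CCN(c2cccc(C(F)(F)F)c2)CC1)N(c1ccccc1)c1ccccc1` is the one compound with a number, and in this assay compound 3 gives 48 mg/kg.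

Of the measured steps, a step that the two limits leave unreadable from compound 1 to compound 2 cannot be sized, a step that the limit leaves unreadable from compound 1 to compound 3 cannot be sized either, and the same holds for a step that the limit leaves unreadable from compound 2 to compound 3. What the three values share is the limit of > 40 mg/kg in this assay, at which 2 of the 3 values shown sit, so none of them sets a direction for a change on the same ring nitrogen.

The change to compound 4 is 2-methoxyphenyl in place of 4-methylphenyl on an amine nitrogen in a ring. With no readable step among the measured compounds, the step that the limit leaves unreadable from compound 1 to compound 4 is expected to stay within the scatter, and compound 4 is expected to remain near the same limit of the assay, so that a limit rather than a number is the likelier outcome. Compound 4 is estimated at 45 mg/kg, with a range from 25 mg/kg to 90 mg/kg.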

Compound 4, dose for half-maximal effect: 50.4 mg/kg
Compound 4: middle estimate off by 1.1-fold (0.05 log units), on the low side; low and high end bracket the measured number.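

In this assay, for the compounds shown here, compound 4 gives a second real number for a group on this ring nitrogen, where the earlier compounds offered only one number and two limits. Going by these compounds alone, the one readable comparison is a 1.1-fold higher number from compound 3 to compound 4 (0.02 log units; within the scatter), so 2-methoxyphenyl, which brings an oxygen and a hydrogen-bond acceptor, cannot be told apart from 3-(trifluoromethyl)phenyl on an amine nitrogen in a ring in this read-out. The steps from compound 1 and from compound 2 to compound 4 cannot be read, so the change from 4-methylphenyl itself has no size, and the series still stands partly at a limit: the limit of > 40 mg/kg in this assay, at which 2 of the 4 values shown sit.

On these data alone, whether compound 1 and compound 2 would fall close to the two numbers or far from them remains open, as does whether any group at this place can move the read-out beyond the scatter. A carboxylic acid, an amine or a nitrile on the aromatic ring could test that, and the compounds shown do not say how such groups would read in this assay.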